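Aryl enone pyrazoles: dichlorophenyl replacing aminophenyl

The source may report more compounds than this note shows. Statements on the series, on what has been measured and on what is new or still open speak of the compounds shown alone.

Two members of this series have been measured in a functional assay on SF-268 cells (Homo sapiens) for cytotoxicity, read by sulforhodamine B assay, with a stated time of 48 h, tested at 0.1 uM; on this read-out lower numbers stand for a stronger effect and higher numbers for a weaker effect at the one concentration tested. Compound 1 `COc1cc(-c2cc(/C=C/C(=O)c3ccc(N)cc3)[nH]n2)cc(OC)c1OC` gives 106%, and compound 2 `COc1ccc(-c2cc(/C=C/C(=O)c3ccc(OC)c(OC)c3)[nH]n2)cc1` gives 99%. Compound 1 holds the higher of the two numbers, but its gap to compound 2 lies within the scatter, so the pair shows no real difference: neither compound produces a noticeable effect at the concentration tested.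

Compound 3 `COc1cc(-c2cc(/C=C/C(=O)c3ccc(Cl)c(Cl)c3)[nH]n2)cc(OC)c1OC` differs from compound 1 in one place: 3,4-dichlorophenyl in place of 4-aminophenyl on a carbonyl carbon. Going by the values given here, no step between two measured compounds covers this kind of exchange, so the expectation rests on the two numbers alone. Because compound 1 gives 106% and compound 2 gives 99%, both near the no-effect level, no step beyond the scatter is expected in this assay for compound 3. The step from compound 1 to compound 3 is estimated as a number 6 percentage points lower from compound 1 to compound 3 (within the scatter). Compound 3 is therefore expected to give about 100%, within a range of 86% to 112%.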

Compound 3, a percentage reported as activity, at one concentration (the size of the read-out at that concentration, not a potency): 92%
Estimate against measurement, compound 3: 8 percentage points above, and the stated range covers the measured number.
By their numbers in this assay, from the lowest: compounds 3, 2 and 1 (each within the scatter of the next, the first and the last beyond it).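

Going by these compounds alone, on a carbonyl carbon, 3,4-dichlorophenyl in place of 4-aminophenyl gives the first step beyond the scatter in this assay: a number 14 percentage points lower from compound 1 to compound 3 (beyond the scatter). This shows that the read-out responds, though only modestly, to the aryl group at this position, with the trimethoxyphenyl side of the core of compound 1 left unchanged. The exchange removes the hydrogen-bond donor and acceptor counted on 4-aminophenyl and adds two chlorine atoms, but nothing here separates these differences or explains the step.

Still open, from the compounds shown here alone, is whether 4-chlorophenyl alone, or an unsubstituted phenyl, would give a similar step. Going by these compounds, it is also open whether a 4-hydroxyphenyl or a 4-dimethylaminophenyl at this position would stay close to compound 1 or move with compound 3.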